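The source may report more compounds than this note shows. Statements on the series, on what has been measured and on what is new or still open speak of the compounds shown alone.

Measured so far: compound 1 `CC(=O)OC[C@H]1O[C@@H](n2cc(-c3cc(C)no3)c(=O)[nH]c2=O)C[C@@H]1OC(C)=O` with 90.8%; compound 2 `CC(=O)OC[C@H]1O[C@@H](n2cc(-c3cc(-c4ccc(C(C)C)cc4)no3)c(=O)[nH]c2=O)C[C@@H]1OC(C)=O` with 56.4%.

Among the measured compounds shown here, in a functional assay on NUGC-3 cells (Homo sapiens) for cytotoxicity, read by sulforhodamine B assay, tested at 10 uM (a lower number here means less inhibition, a higher number more inhibition at the concentration tested (going by the name of the read-out)), compound 2 stands lowest of the two numbers; the nearest is compound 1, and the only measured step, a number 34.4 percentage points lower from compound 1 to compound 2 (beyond the scatter), was large and beyond the scatter. That step exchanges methyl for the whole 4-isopropylphenyl and so does not test a change inside the alkyl on the phenyl.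

Compound 3 `CCCCc1ccc(-c2cc(-c3cn([C@H]4C[C@H](OC(C)=O)[C@@H](COC(C)=O)O4)c(=O)[nH]c3=O)on2)cc1` differs from compound 2 by butyl in place of isopropyl on an aromatic carbon. For the measured compounds named here, no measured step bears directly on this exchange, so no step beyond the scatter is expected: a number 3.4 percentage points lower from compound 2 to compound 3 (within the scatter). Compound 3 is therefore estimated at 53%, with a range of 32% to 74%.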

Compound 3, a percentage reported as inhibition, at one concentration (the size of the read-out at that concentration, not a potency): 39.8%
Compound 3: middle estimate off by 13.2 percentage points, on the high side; the measured number falls inside the stated range.
By their numbers in this assay, from the lowest: compound 3; then compound 2; then compound 1.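

In this assay, butyl in place of isopropyl gives a number 16.6 percentage points lower from compound 2 to compound 3 (beyond the scatter), so a change inside the alkyl on the phenyl, and not only the exchange of the whole group, shifts the read-out. Replacing methyl with the whole 4-butylphenyl gives a number 51 percentage points lower from compound 1 to compound 3 (beyond the scatter). Nothing measured on these compounds accounts for either step.

Isopropyl and butyl differ in both branching and chain length, so the two remain unseparated here. From the compounds shown here alone, whether hexyl, tert-butyl, an amine or a carboxylic acid on the phenyl would continue this trend remains open.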